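The source may hold more compounds than are shown below. What is called first, only, known or untested is meant among the compounds shown, and "the series" means these compounds.

Measured compounds:
compound 1 `CCCN(c1nccc(-c2c(OC)cc(OC)cc2OC)n1)C(C1CC1)C1CC1`: 15 nM
compound 2 `CCCN(c1nccc(-c2c(OC)cc(OC)cc2OC)n1)C1(c2ccsc2)CC1`: 2000 nM
compound 3 `CCCN(c1nccc(-c2c(OC)cc(OC)cc2OC)n1)C1CCCC1`: 2200 nM

In an assay on CHO cells for displacement of a labelled ligand from corticotropin-releasing factor receptor 1 (Homo sapiens) (on this read-out lower numbers stand for stronger inhibition and higher numbers for weaker inhibition), compound 1 gives the lowest number of the three, and both other compounds lie far from it: a 130-fold higher number from compound 1 to compound 2 (2.12 log units; beyond the scatter) and a 150-fold higher number from compound 1 to compound 3 (2.17 log units; beyond the scatter). Compound 4 `CCCN(c1nccc(-c2c(F)cc(OC)cc2OC)n1)C(C1CC1)C1CC1` differs from compound 1 by fluoro in place of methoxy on an aromatic carbon. Neither measured step bears on this change, since each of them alters the group on the nitrogen and leaves the aromatic ring untouched. With no guide among the measured compounds, the step for compound 4 is expected to be small, at most modestly weaker, a 2.0-fold higher number from compound 1 to compound 4 (0.30 log units; within the scatter). Compound 4 is therefore estimated at 30 nM, with a range from 8 nM to 120 nM.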

Compound 4, inhibition constant: 63 nM
The estimate for compound 4 lay 2.1-fold (0.32 log units) below the measured number; low and high end bracket the measured number.
By their numbers in this assay, from the lowest: compound 1; then compound 4; then compounds 2 and 3 (each within the scatter of the next).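

In this assay, fluoro in place of methoxy on an aromatic carbon gives a 4.2-fold higher number from compound 1 to compound 4 (0.62 log units; beyond the scatter), so this position on the aromatic ring also affects the number, which the changes on the nitrogen could not show. The step is modest, whereas those on the nitrogen were large, and compound 4 keeps a number well short of those of compounds 2 and 3. Nothing measured here accounts for this step. Going by these compounds, whether chloro or methyl at this position would stay closer to compound 1 remains open, as does whether the step would carry over to compounds with cyclopentyl on the nitrogen.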